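Taking the nitro group off compound 3

The compounds below may be only part of what the source reports. "The series", "measured", "known", "first", "only" and "open" are said of these compounds alone.

Going by the values given here, in an ADME assay on BHK-21 cells (Mesocricetus auratus) for cytotoxicity, read by MTT assay, with a stated time of 96 h (on this read-out lower numbers stand for higher toxicity in this test and higher numbers for lower toxicity in this test), compound 3 `O=[N+]([O-])c1cccc(/N=N/N2CCCC2)c1` gives 42000 nM, the only true number among the three values available. Compound 1 `Clc1cccc(/N=N/N2CCCC2)c1` reads > 100000 nM, which is a limit of the assay. Compound 2 `O=[N+]([O-])c1ccc(/N=N/N2CCCC2)cc1` reads >= 100000 nM, which is also a limit of the assay.

Compound 4 `c1ccc(/N=N/N2CCCC2)cc1` has not yet been measured. It differs from compound 3 by hydrogen in place of nitro on an aromatic carbon. Among the compounds with values here, the one measured step that bears on this change is an at least 2.3-fold lower number from compound 1 to compound 3 (0.37 log units; beyond the scatter), with nitro in place of chloro on an aromatic carbon. Compound 2 goes against any simple rule, as it carries nitro too and still ends at a limit. Taking the step to compound 3 in reverse as a rough guide, a higher number of similar size is expected, and the reading may reach the limit of this assay. The expected change is a 2.0-fold higher number from compound 3 to compound 4 (0.31 log units; beyond the scatter). For compound 4 the estimate is 85000 nM, with an expected range of 40000 nM to 150000 nM.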

Compound 4, half-maximal cytotoxic concentration: >= 100000 nM
Compound 4 gave a limit, no number; the forecaster's own chance of this, stated with the estimate: 55%; middle value at least 1.1-fold (0.07 log units) from the limit.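

In this assay, going by these compounds alone, hydrogen in place of nitro on this aromatic carbon gives an at least 2.3-fold higher number from compound 3 to compound 4 (0.37 log units; beyond the scatter), so the one readable number depends on the nitro group and not on the shared core alone. The core with only hydrogen at this place is not the source of that reading, although compound 2 goes against any simple rule about nitro, since it carries the group and still gives no number. The steps from compound 1 and from compound 2 to compound 4 cannot be read, and compound 4 ends at a limit shared with compound 2: the limit of >= 100000 nM in this assay, at which 2 of the 4 values shown sit.

On these data alone, how far compound 4 lies beyond its limit remains open, and so does any ranking of it against compound 1 and compound 2. Also open, as far as these compounds go, is whether an amine or a carboxylic acid at this place would lower the number as nitro does.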